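The compounds below may be only part of what the source reports. "The series", "measured", "known", "first", "only" and "open" are said of these compounds alone.

Compound 1 `O=C(NCc1ccc(OCc2ccccc2)cc1)n1cccn1` gives 900 nM in an assay on membranes from brain for binding affinity to Monoglyceride lipase (Mus musculus), read by fluorescence, with stated times of 1 h and 30 min; on this read-out higher numbers stand for weaker inhibition and lower numbers for stronger inhibition. Compound 2 `N#Cc1cnn(C(=O)NCc2ccc(OCc3ccccc3)cc2)c1` differs from compound 1 by cyano in place of hydrogen on an aromatic carbon and in this assay compound 2 gives 100 nM, a step of a 9.0-fold lower number from compound 1 to compound 2 (0.95 log units; beyond the scatter). Compound 3 `CN(CCN(C)C(=O)n1cccn1)Cc1cccc(OCc2ccccc2)c1` carries a different core; the difference between the two cores is not broken down here. In this assay compound 3 gives 4600 nM, the highest of the three numbers, beyond the scatter from compound 1 and from compound 2. Compound 4 `CN(CCN(C)C(=O)n1cc(C#N)cn1)Cc1cccc(OCc2ccccc2)c1` is not yet measured; it differs from compound 3 by cyano in place of hydrogen on an aromatic carbon, the same change as that from compound 1 to compound 2, at the same place. Going by the values given here, for compound 4 a step of a 6.6-fold lower number from compound 3 to compound 4 (0.82 log units; beyond the scatter) is expected in this assay, resting on the step of a 9.0-fold lower number from compound 1 to compound 2 (0.95 log units; beyond the scatter) seen on the other core; only one such pair is available, so the range is kept wide. Compound 4 is thus estimated at 700 nM, between 250 nM and 2000 nM.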

Compound 4, half-maximal inhibitory concentration: 590 nM
The estimate for compound 4 lay 1.2-fold (0.07 log units) above the measured number, within the range that was stated.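

The change from 1H-pyrazol-1-yl to 4-cyano-1H-pyrazol-1-yl gives a 7.8-fold lower number from compound 3 to compound 4 (0.89 log units; beyond the scatter) in this assay. The size of the step carries over between the two cores: the same change on two cores in this assay, a 9.0-fold lower number (0.95 log units; beyond the scatter) from compound 1 to compound 2 and a 7.8-fold lower number (0.89 log units; beyond the scatter) from compound 3 to compound 4, 1.2-fold (0.06 log units) apart, within the scatter of two such steps

Going by these compounds alone, this rests on a single change and only two pairs of compounds, so it does not show that the step would hold on any further core, nor does it explain the difference between the cores themselves.

Still open, as far as these compounds go, is whether another group at the same place, such as a carboxylic acid, an amine or trifluoromethyl, would give a step of similar size. Also open, from the compounds shown here alone, is whether a longer chain in the core would leave the cyano step intact.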